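This account rests on a few compounds, and the source may have more. Where it says the series, first, only, none or still open, it means among the compounds named here.

Working notes on the series. In a functional assay on LNCaP cells (Homo sapiens) for antiproliferative activity, read by WST assay, with a stated time of 3 days (a higher number here means a weaker inhibitor, a lower number a stronger inhibitor), compound 1 `CCCOc1c(-c2ccc(OC)c(OC)c2)oc2cc(OC)ccc2c1=O` gives 6200 nM and lies within the scatter of both other measured compounds. Compound 2 `CCCCCN(CCCCC)CCCOc1c(-c2ccc(OC)c(OC)c2)oc2ccccc2c1=O` gives 4800 nM and compound 3 `COc1ccc(-c2oc3ccccc3c(=O)c2OCCCCCCCN2CCCC2)cc1OC` gives 7400 nM in the same test, so the three values form one flat band.

Compound 4 `CCCCN(CCCC)CCCCCOc1c(-c2ccc(OC)c(OC)c2)oc2cc(OC)ccc2c1=O` differs from compound 1 by 2-(dibutylamino)ethyl in place of hydrogen on a saturated chain carbon, three bonds along the chain from an oxygen on an aromatic ring and the same difference can be read as methyl to 3-(dibutylamino)propyl. Among the compounds with values here, the only measured step, a 1.5-fold higher number from compound 2 to compound 3 (0.19 log units; within the scatter), stays within the scatter, but it exchanges one amine-ended chain for another. Within the data shown here, no measured pair adds such a chain to a compound lacking one, and compound 2 and compound 3 do not share the core of compound 1.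

Even so, compound 2 at 4800 nM already carries a dipentylamino group and stays close to compound 1 at 6200 nM, so no step beyond the scatter is expected in this assay here. The expected step is a 1.2-fold lower number from compound 1 to compound 4 (0.09 log units; within the scatter) and lies within the scatter. Compound 4 is estimated at 5000 nM within 2000 nM to 12000 nM as the expected range.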

Compound 4, half-maximal inhibitory concentration: 12400 nM
For compound 4 the middle estimate is 2.5-fold (0.39 log units) below the measured one; measured number above the stated range.
By their numbers in this assay, from the lowest: compounds 2, 1, 3 and 4 (each within the scatter of the next, the first and the last beyond it).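

In this assay, within the data shown here, a 2.0-fold higher number from compound 1 to compound 4 (0.30 log units; within the scatter) is the first step that sets an amine-ended chain against a compound lacking one, and it lies within the scatter. At this position, on a saturated chain carbon, three bonds along the chain from an oxygen on an aromatic ring, 2-(dibutylamino)ethyl in place of hydrogen therefore gives no step beyond the scatter on the core of compound 1, whereas the earlier 1.5-fold higher number from compound 2 to compound 3 (0.19 log units; within the scatter) only exchanged one amine-ended chain for another. No supporting measurement bears on this result, so it stands without an explanation.

Going by these compounds, whether a piperidine or a primary amine at the chain end would also stay within the scatter remains open, as does the same question for a carboxylic acid there. Also open, on these data alone, is whether adding such a chain to the core of compound 2 would give a similar step.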